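Swapping the triazole for an oxazole on the shared core

The source may report more compounds than this note shows. Statements on the series, on what has been measured and on what is new or still open speak of the compounds shown alone.

Measured compounds:
- compound 1, `COc1cc(N2CCN(C(=O)N[C@@H](C)c3cccc4ccccc34)CC2)ccc1-n1cnc(C)n1`: 110 mL.min-1.g-1
- compound 2, `COc1cc(N2CCN(C(=O)Cn3cnc4ccc(C(F)(F)F)cc43)C[C@@H]2C)ccc1-c1cnc(C)o1`: 50 mL.min-1.g-1

In an ADME assay on microsomes from liver (Rattus norvegicus) for metabolic stability, read by LC-MS (on this read-out higher numbers stand for fast clearance and lower numbers for slow clearance), compound 1 gives 110 mL.min-1.g-1, the higher of the two numbers recorded. Compound 2 gives 50 mL.min-1.g-1 in this assay, a gap beyond the usual scatter, but compound 2 differs from compound 1 in several places at once, so no single change can be read from that pair.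

Compound 3, `COc1cc(N2CCN(C(=O)N[C@@H](C)c3cccc4ccccc34)CC2)ccc1-c1cnc(C)o1`, has not yet been measured. It differs from compound 1 in one place: 2-methyl-1,3-oxazol-5-yl in place of 3-methyl-1H-1,2,4-triazol-1-yl on an aromatic carbon, sitting on an aromatic carbon of a six-membered ring, ortho to a methoxy group and para to a large group.

For the measured compounds named here, no measured step isolates this change. Going by the values given here, the only pointer is that compound 2, which carries the same 2-methyl-1,3-oxazol-5-yl group, gave 50 mL.min-1.g-1. Compound 3 is therefore expected to show a 1.4-fold lower number from compound 1 to compound 3 (0.14 log units; within the scatter), a modest move downward that may well stay within the scatter. The estimate for compound 3 is 80 mL.min-1.g-1, in a range from 40 mL.min-1.g-1 to 170 mL.min-1.g-1.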

Compound 3, intrinsic clearance in microsomes: 130 mL.min-1.g-1
Compound 3: the middle estimate sits 1.6-fold (0.21 log units) below what was measured; the measured number falls inside the stated range.
By their numbers in this assay, from the lowest: compound 2; then compounds 1 and 3 (each within the scatter of the next).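

In this assay, placing 2-methyl-1,3-oxazol-5-yl where 3-methyl-1H-1,2,4-triazol-1-yl stood gives a 1.2-fold higher number from compound 1 to compound 3 (0.07 log units; within the scatter). For the compounds shown here, this is the first comparison to isolate a single change at this position on an aromatic carbon, ortho to a methoxy group and para to a large group, and on the core of compound 1 the read-out does not separate the two five-membered aromatic rings. No measurement on hand offers an explanation for this result.

Going by these compounds alone, whether the exchange would read the same way alongside the other groups of compound 2 remains open, as no pair of compounds tests it there. Also open, on these data alone, is whether a different group at this position, such as a primary amine, a carboxylic acid or a longer alkyl chain, would shift the number beyond the scatter.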